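Swapping acetyl for benzyl on the aromatic nitrogen

The source may hold more compounds than are shown below. What is called first, only, known or untested is meant among the compounds shown, and "the series" means these compounds.

Of the compounds shown here, three sharing one core have been tested in a functional assay on KB cells (Homo sapiens) for cytotoxicity; on this read-out lower numbers stand for stronger inhibition and higher numbers for weaker inhibition. Compound 1 `COc1ccc(S(=O)(=O)N2CCc3cccc(NC(=O)c4cccs4)c32)cc1` gives 43 nM, compound 2 `COc1ccc(S(=O)(=O)N2CCc3cccc(NC(=O)c4ccc(F)cc4)c32)cc1` gives 85 nM, and compound 3 `COc1ccc(S(=O)(=O)N2CCc3cccc(NC(C)=O)c32)cc1` gives 90 nM. Compound 3 cannot be told apart from compound 2 and lies a modest step on the weaker side of compound 1. The two measured steps that show this are a 1.1-fold higher number from compound 2 to compound 3 (0.02 log units; within the scatter) and a 2.1-fold higher number from compound 1 to compound 3 (0.32 log units; beyond the scatter).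

Compound 4 `COc1ccc(S(=O)(=O)N2CCc3cccc(NCc4ccccc4)c32)cc1` has not yet been measured. Its difference from compound 3 is benzyl in place of acetyl on a nitrogen on an aromatic ring. In words, this is benzyl in place of acetyl on a nitrogen on an aromatic ring, so the carbonyl leaves with the acetyl.

The measured steps bear on this only in part. Each exchanges a group on a carbonyl carbon, and the largest is a 2.1-fold higher number from compound 1 to compound 3 (0.32 log units; beyond the scatter). None removes the carbonyl, so the data do not show what that removal does. This change goes further than any measured one, so a step towards weaker inhibition is expected, though with wide uncertainty. The estimated step is a 2.0-fold higher number from compound 3 to compound 4 (0.30 log units; within the scatter). The expected value for compound 4 is 180 nM, within an estimated range of 45 nM to 700 nM.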

Compound 4, half-maximal inhibitory concentration: > 10000 nM
Compound 4: only a limit was reported; the forecaster's own chance of this, stated with the estimate: 5%; middle value at least 55-fold (1.74 log units) away from the limit.
By their numbers in this assay, from the lowest: compounds 1, 2 and 3 (each within the scatter of the next, the first and the last beyond it). At a limit, above all of these: compound 4.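

In this assay, compound 4 can be read only as a limit, not as a number: the limit of > 10000 nM in this assay, at which 1 of the 4 values shown sits. The earlier steps shown here only exchanged the group on the carbonyl and were modest at most, whereas replacing acetamido with benzylamino gives an at least 110-fold higher number from compound 3 to compound 4 (2.04 log units; beyond the scatter), and the comparisons with the two ring-bearing amides are just as large, with an at least 110-fold higher number from compound 2 to compound 4 (2.07 log units; beyond the scatter) and an at least 230-fold higher number from compound 1 to compound 4 (2.36 log units; beyond the scatter). Compounds 1 and 2 also carry an aromatic ring on this side of the shared core, so at this position a ring alone does not go with the loss of inhibition, while this particular change from amide to benzylamino does.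

Still open, on these data alone, is whether the loss follows from the carbonyl leaving or from the particular way benzyl places its ring on the nitrogen, as the two changes arrive together in compound 4. An ethyl group or a plain amine at the same place, with neither carbonyl nor ring, would help to separate these two effects.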